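Shortening the sulfonyl substituent of compound 3

This account rests on a few compounds, and the source may have more. Where it says the series, first, only, none or still open, it means among the compounds named here.

Of the compounds shown here, three sharing one core have been measured in a physicochemical assay for permeability, using PAMPA, at pH 7.4; a higher number here means that the compound crosses the layer faster, a lower number that the compound crosses the layer more slowly. Compound 1 `O=C(NS(=O)(=O)c1ccc(F)cc1)c1ccc(Nc2nc(NC3(c4ccc(Cl)cc4)CC3)nc(OCC(F)(F)F)n2)cc1` gives 193 nm/s, compound 2 `CC(C)S(=O)(=O)NC(=O)c1ccc(Nc2nc(NC3(c4ccc(Cl)cc4)CC3)nc(OCC(F)(F)F)n2)cc1` gives 31 nm/s, and compound 3 `CC(C)OC(=O)NCCS(=O)(=O)NC(=O)c1ccc(Nc2nc(NC3(c4ccc(Cl)cc4)CC3)nc(OCC(F)(F)F)n2)cc1` gives 71 nm/s, which places compound 3 second of the three. Compound 4 `CS(=O)(=O)NC(=O)c1ccc(Nc2nc(NC3(c4ccc(Cl)cc4)CC3)nc(OCC(F)(F)F)n2)cc1` differs from compound 3 by hydrogen in place of ((isopropoxycarbonyl)amino)methyl on a saturated chain carbon bound to a sulfonyl sulfur. Within the data shown here, the steps that bear on this change are a 2.3-fold higher number from compound 2 to compound 3 (0.36 log units; beyond the scatter) and a 2.7-fold lower number from compound 1 to compound 3 (0.43 log units; beyond the scatter); in both, only the group on the sulfonyl sulfur changed, and this assay shifted modestly each time. Along this line, the step from compound 3 to compound 4 is expected to be a 2.4-fold lower number from compound 3 to compound 4 (0.37 log units; beyond the scatter). The estimate for compound 4 in this assay is 30 nm/s, with a range from 12 nm/s to 80 nm/s.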

Compound 4, apparent permeability: 11 nm/s
The estimate for compound 4 lay 2.7-fold (0.44 log units) above the measured number, and the stated range ends above it.
By their numbers in this assay, from the lowest: compound 4; then compound 2; then compound 3; then compound 1.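

In this assay, methyl on the sulfonyl sulfur sits lowest of the four groups, with a 6.5-fold lower number from compound 3 to compound 4 (0.81 log units; beyond the scatter), a 2.8-fold lower number from compound 2 to compound 4 (0.45 log units; beyond the scatter) and an 18-fold lower number from compound 1 to compound 4 (1.24 log units; beyond the scatter). Even the small step up from methyl to isopropyl is beyond the scatter, so this position responds across its whole range. The order does not simply follow group size, however, since compound 1, with 4-fluorophenyl, stands above compound 3, with its longer chain.

Nothing measured here explains these steps. Going by these compounds, how a cyclopropyl, a phenyl without fluorine, or an amine at the chain end would fall in this order remains open.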